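This account rests on a few compounds, and the source may have more. Where it says the series, first, only, none or still open, it means among the compounds named here.

Compound 2 `COc1ccc(/C=C/C(=O)c2cccc(-c3cccc(F)c3)c2)cc1O` and compound 1 `COc1cc(/C=C/C(=O)c2cccc(-c3cccc(F)c3)c2)ccc1O` are isomers of one another. In an assay on A549 cells for inhibition of transcription factor p65 (Homo sapiens), read by fluorescence, with a stated time of 2 h (on this read-out higher numbers stand for weaker inhibition and lower numbers for stronger inhibition), compound 2 gives 9590 nM, the smaller of the two numbers shown, while compound 1 gives 12900 nM; that gap lies within the scatter, so the two cannot be told apart. Compound 3 `COc1ccc(/C=C/C(=O)c2cccc(-c3cccc(F)c3)c2)cc1OC` carries methyl in place of hydrogen on an oxygen on an aromatic ring. For the measured compounds named here, no measured pair shows this change, so no step beyond the scatter is expected in either direction. Compound 3 is estimated in this assay at 12000 nM, with a range from 4000 nM to 36000 nM. That estimate means an expected step of a 1.3-fold higher number from compound 2 to compound 3 (0.10 log units; within the scatter).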

Compound 3, half-maximal inhibitory concentration: 33400 nM
The estimate for compound 3 lay 2.8-fold (0.44 log units) below the measured number; the measured number falls inside the stated range.
By their numbers in this assay, from the lowest: compounds 2 and 1 (each within the scatter of the next); then compound 3.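

In this assay the change from hydroxy to methoxy gives a 3.5-fold higher number from compound 2 to compound 3 (0.54 log units; beyond the scatter) and a 2.6-fold higher number from compound 1 to compound 3 (0.41 log units; beyond the scatter), the first steps beyond the scatter among these compounds. Where compound 1 and compound 2 could not be told apart, methyl in place of hydrogen on this oxygen modestly weakens inhibition. Nothing available explains this step. Still open, as far as these compounds go, is whether a longer chain on that oxygen, such as ethyl, would weaken inhibition further, and how an amine in place of the hydroxy would read.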